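This account rests on a few compounds, and the source may have more. Where it says the series, first, only, none or still open, it means among the compounds named here.

Compound 1 `CCOC(=O)c1nn(-c2ccccc2)/c(=N/c2nc(-c3c(C)n(C)n(-c4ccccc4)c3=O)cs2)s1`: > 100000 nM
Compound 2 `CCOC(=O)c1nn(-c2ccc(C)cc2)/c(=N/c2nc(-c3c(C)n(C)n(-c4ccccc4)c3=O)cs2)s1`: > 100000 nM

In a functional assay on MCF7 cells (Homo sapiens) for cytotoxicity, read by sulforhodamine B assay, with a stated time of 72 h (on this read-out lower numbers stand for stronger inhibition and higher numbers for weaker inhibition), compound 1 gives > 100000 nM, which is a limit of the assay and not a number. In this assay compound 2 likewise gives > 100000 nM, again a limit. Among the compounds with values here, the one step between measured compounds, a step that the two limits leave unreadable from compound 1 to compound 2, can therefore not be read in size or direction, since both values sit at the limit of > 100000 nM in this assay, at which 2 of the 2 values shown sit. Compound 2 thus stands only at a limit, with no number of its own, and so does compound 1.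

Compound 3 `CCOC(=O)c1nn(-c2ccc(OC)cc2)/c(=N/c2nc(-c3c(C)n(C)n(-c4ccccc4)c3=O)cs2)s1` differs from compound 2 by methoxy in place of methyl on an aromatic carbon. Within the data shown here, no measured step bears on this change in a readable way, so the data give no basis for expecting a step of any size or direction in this assay; the most that can be said is that the two measured compounds both stayed at the limit.

Compound 3 is therefore expected at about 150000 nM, within 30000 nM to 1000000 nM. This corresponds to an expected step that the limit leaves unreadable from compound 2 to compound 3.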

Compound 3, half-maximal inhibitory concentration: 15900 nM
Compound 3: the middle estimate sits 9.4-fold (0.97 log units) above what was measured; the whole stated range lies above it.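

In this assay, within the data shown here, compound 3 gives the first readable number in this set, so a change on this aromatic carbon, para to a large group, can register on the read-out. Methoxy in place of methyl gives an at least 6.2-fold lower number from compound 2 to compound 3 (0.79 log units; beyond the scatter), and methoxy in place of hydrogen gives an at least 6.2-fold lower number from compound 1 to compound 3 (0.79 log units; beyond the scatter). Both steps are only minimum sizes because compound 1 and compound 2 each stand at a limit of the assay and have no number of their own: the limit of > 100000 nM in this assay, at which 2 of the 3 values shown sit.

On these data alone, the true size of these two steps stays open, and the step between hydrogen and methyl cannot be read at all. Also open, as far as these compounds go, is whether an ethoxy group, a hydroxyl or an amine on this same carbon would lower the number further, leave it unchanged or return it to the limit.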